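Butoxycarbonyl to isobutoxycarbonyl on the shared core

The source may hold more compounds than are shown below. What is called first, only, known or untested is meant among the compounds shown, and "the series" means these compounds.

Of the compounds shown here, two on the shared core have been measured in a functional assay on the whole organism with Scenedesmus acutus as the target, with a stated time of 20 h; on this read-out higher numbers stand for weaker inhibition and lower numbers for stronger inhibition. Compound 1 `CC(C)OC(=O)c1cc(N2C(=O)C3=C(CCCC3)C2=O)ccc1Cl` gives 182 nM. Compound 2 `CCCCOC(=O)c1cc(N2C(=O)C3=C(CCCC3)C2=O)ccc1Cl` gives 7760 nM, the higher of the two numbers and so the weaker inhibition.

Compound 3 `CC(C)COC(=O)c1cc(N2C(=O)C3=C(CCCC3)C2=O)ccc1Cl` has not yet been measured. It differs from compound 2 as follows: isopropyl in place of propyl on a saturated chain carbon bound to an oxygen next to a carbonyl group. This is isopropyl in place of propyl on a saturated chain carbon bound to an oxygen next to a carbonyl group, or butyl to isobutyl when cut one bond further out.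

Among the compounds with values here, only one measured step bears on this change: a 43-fold higher number from compound 1 to compound 2 (1.63 log units; beyond the scatter), large and beyond the scatter, with butyl in place of isopropyl. Compound 3 keeps an isopropyl end, as compound 1 does, but the change is not the same, and a single step is thin evidence. A partial return towards compound 1 is therefore expected, with a lower number than compound 2 but a smaller move than the measured one. The expected step is a 6.5-fold lower number from compound 2 to compound 3 (0.81 log units; beyond the scatter). In this assay compound 3 is estimated at 1200 nM, with an expected range of 250 nM to 6000 nM.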

Compound 3, half-maximal inhibitory concentration: 15500 nM
For compound 3 the middle estimate is 13-fold (1.11 log units) below the measured one; measured number above the stated range.
By their numbers in this assay, from the lowest: compound 1; then compounds 2 and 3 (each within the scatter of the next).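

In this assay the change from propyl to isopropyl on a saturated chain carbon bound to an oxygen next to a carbonyl group gives a 2.0-fold higher number from compound 2 to compound 3 (0.30 log units; within the scatter) and so does not separate the butyl and isobutyl groups on the shared core. Having an isopropyl end is therefore not enough to match compound 1, since isobutyl in place of isopropyl on an oxygen next to a carbonyl group gives an 85-fold higher number from compound 1 to compound 3 (1.93 log units; beyond the scatter) and this is a large step, like the one seen with butyl. Among these three compounds, only compound 1 stands apart, and no measurement on hand accounts for that difference.

The compounds shown leave open whether the low number belongs to isopropyl alone or is shared by other small groups on the same oxygen, such as ethyl, cyclopropyl or tert-butyl. On these data alone, the response to a longer chain such as hexyl, or to a free carboxylic acid or an amide in place of the oxygen-linked group, also remains open.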